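Extending the Chain of a Compound at the Limit

This account rests on a few compounds, and the source may have more. Where it says the series, first, only, none or still open, it means among the compounds named here.

The set rests on the core shown in compound 1 `CCCc1nnsc1CO/N=C/c1c(C)nn(C)c1Oc1ccc(F)cc1`, which in a functional assay on SGC-7901 cells (Homo sapiens) for inhibition, read by MTT assay, with a stated time of 48 h (on this read-out higher numbers stand for weaker inhibition and lower numbers for stronger inhibition), gives 8640 nM. Compound 2 `CCCc1nnsc1CO/N=C/c1c(C)nn(C)c1Oc1ccc(Cl)cc1` carries chloro in place of fluoro on an aromatic carbon, and in this assay compound 2 gives 18600 nM; the step of a 2.2-fold higher number from compound 1 to compound 2 (0.33 log units; beyond the scatter) is the only measured step among these compounds. Compound 3 `Cc1nnsc1CO/N=C/c1c(C)nn(C)c1Cl` lacks the aryloxy group of the other two and carries a shorter chain. In this assay compound 3 reaches only > 50000 nM, which is a limit of the assay rather than a number, the case recorded in the limit of > 50000 nM in this assay, at which 1 of the 3 values shown sits. Compound 3 therefore stands at the far end of what the numbers show.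

Compound 4 `CCCc1nnsc1CO/N=C/c1c(C)nn(C)c1Cl` is the unmeasured partner of compound 3, differing by ethyl in place of hydrogen on a saturated chain carbon bound to an aromatic carbon. Within the data shown here, no measured step covers this change, since the single measured step concerns a halogen on an aromatic carbon and not the chain. Among the measured compounds shown here, with compound 3 at the limit and no step to guide the direction, compound 4 is expected to remain close to where compound 3 stands, so the estimated step of an at least 1.1-fold lower number from compound 3 to compound 4 (0.04 log units; that floor lies within the scatter) is expected to be small. In this assay compound 4 is estimated at 45000 nM, within a range from 15000 nM to 150000 nM.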

Compound 4, half-maximal inhibitory concentration: > 50000 nM
Compound 4: only a limit was reported; the forecaster's own chance of this, stated with the estimate: 60%; at least 1.1-fold (0.04 log units) between middle value and limit.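

With the propyl chain in place and chloro on the aromatic carbon, compound 4 gives in this assay only a limit of the assay, > 50000 nM. The propyl chain alone therefore does not bring a chloro compound to a readable number, and the change on the aromatic carbon now has a size, if only a minimum one: chloro in place of 4-chlorophenoxy gives an at least 2.6-fold higher number from compound 2 to compound 4 (0.42 log units; beyond the scatter), and chloro in place of 4-fluorophenoxy gives an at least 5.7-fold higher number from compound 1 to compound 4 (0.76 log units; beyond the scatter). The step for ethyl in place of hydrogen on the saturated chain carbon cannot be read, as compound 3 and compound 4 both rest at the same limit: the limit of > 50000 nM in this assay, at which 2 of the 4 values shown sit.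

The compounds shown leave open how the chain length acts when an aryloxy group is present, for compound 1 and compound 2 both carry propyl, and whether a butyl chain would read differently from propyl. They also leave open what an amine or a carboxylic acid on that aromatic carbon, in place of chloro or the halogenated phenoxy groups, would give.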